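From fluoro to chloro on compound 3

A few compounds are considered here, and "the series" means these few. Any claim that something is new, unique, unknown or untested is made for them only; others in the source may bear on it.

In an ADME assay on cells (Peritoneal macrophage cell, Mus musculus) for cytotoxicity, read by fluorescence and resazurin assay, with a stated time of 3 days (a higher number here means that more compound is tolerated, a lower number that less compound is tolerated), compound 3 `O=C(Nc1cc(-c2ccccn2)n[nH]1)N1CCC(c2ccc(F)cc2)CC1` gives > 64000 nM, which is a limit and not a number. Compound 1 `O=C(Nc1cc(-c2ccccn2)n[nH]1)N1CCC(c2cccc(F)c2)CC1` gives > 45000 nM, also a limit. Compound 2 `N#Cc1ccc(OC2CCN(C(=O)Nc3cc(-c4ccccn4)n[nH]3)CC2)cc1` gives > 64000 nM, again a limit. The three results therefore fall into two groups: the limit of > 45000 nM in this assay, at which 1 of the 3 values shown sits, and (the limit of > 64000 nM in this assay, at which 2 of the 3 values shown sit). None of the three compounds has yet given a true half-maximal cytotoxic concentration.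

The next compound, compound 4 `O=C(Nc1cc(-c2ccccn2)n[nH]1)N1CCC(c2ccc(Cl)cc2)CC1`, changes a single atom of compound 3: chloro in place of fluoro on an aromatic carbon. The rest of the molecule stays the same.

Two measured steps lead into compound 3, and neither gives a size. Going by the values given here, the first is a step that the two limits leave unreadable from compound 1 to compound 3, and the second is a step that the two limits leave unreadable from compound 2 to compound 3. The step that the two limits leave unreadable from compound 1 to compound 2 is no more informative. With no readable step to draw on, the expectation rests on the smallness of the change and on the limits seen so far, and it favours no direction. A step beyond the usual scatter is not expected, so the estimated move is an at least 1.0-fold lower number from compound 3 to compound 4 (0.02 log units; that floor lies within the scatter). Another limit would be no surprise. For compound 4, the estimated value is 60000 nM, with an expected range from 30000 nM to 120000 nM.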

Compound 4, half-maximal cytotoxic concentration: > 55000 nM
Compound 4 ended at the assay's limit (the forecaster's own chance of this, stated with the estimate: 65%); the middle value lies beyond the limit too.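

In this assay compound 4 gives > 55000 nM, which is a limit and not a number, so its steps from compound 1, compound 2 and compound 3 cannot be read. The compounds shown leave open where the true half-maximal cytotoxic concentration of any of the four lies, and whether chloro and fluoro differ here at all.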